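This account rests on a few compounds, and the source may have more. Where it says the series, first, only, none or still open, it means among the compounds named here.

Series notes: four esters of one shared core, differing only in the length of the saturated chain on the oxygen next to the carbonyl group. Compound 1 `CCCCCCCCCCCCCOC(=O)CCC(=O)N1CCN(CCCOc2cc3c(Nc4ccc(F)c(Cl)c4)ncnc3cc2OC)CC1` gives 20.6% in a functional assay on A549 cells (Homo sapiens) for cytotoxicity, read by MTT assay, with a stated time of 24 h, tested at 60 uM; on this read-out lower numbers stand for a stronger effect and higher numbers for a weaker effect at the one concentration tested. Compound 2 `CCCCCCCCCCCCCCOC(=O)CCC(=O)N1CCN(CCCOc2cc3c(Nc4ccc(F)c(Cl)c4)ncnc3cc2OC)CC1` gives 84.9% in this assay. Compound 3 `CCCCCCCCCCCCCCCCCCOC(=O)CCC(=O)N1CCN(CCCOc2cc3c(Nc4ccc(F)c(Cl)c4)ncnc3cc2OC)CC1` gives 87.2% in this assay, the highest of the three numbers. Compound 4 `CCCCCCCCCCCCCCCCCCCOC(=O)CCC(=O)N1CCN(CCCOc2cc3c(Nc4ccc(F)c(Cl)c4)ncnc3cc2OC)CC1` is not yet measured.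

From compound 1 to compound 2 the change is methyl in place of hydrogen on a saturated chain carbon, ten or more bonds along the chain from an oxygen next to a carbonyl group, and in this assay it made a large step: a number 64.3 percentage points higher from compound 1 to compound 2 (beyond the scatter). The core of compound 3 differs from the core of compound 1 by pentyl in place of hydrogen on a saturated chain carbon, ten or more bonds along the chain from an oxygen next to a carbonyl group, with the step of a number 66.6 percentage points higher from compound 1 to compound 3 (beyond the scatter). From compound 2 to compound 3, however, the step was a number 2.3 percentage points higher from compound 2 to compound 3 (within the scatter), within the scatter.

From compound 3 to compound 4 the change is methyl in place of hydrogen on a saturated chain carbon, ten or more bonds along the chain from an oxygen next to a carbonyl group, the same change as from compound 1 to compound 2, at the same place. The large earlier step came from compound 1, whose value 20.6% sits far below the others, while the step from compound 2 to compound 3 was a number 2.3 percentage points higher from compound 2 to compound 3 (within the scatter). Compound 4 is therefore expected to move only a number 0.8 percentage points higher from compound 3 to compound 4 (within the scatter) from compound 3. Compound 4 is estimated at 88%, between 72% and 100%.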

Compound 4, a percentage reported as activity, at one concentration (the size of the read-out at that concentration, not a potency): 89.3%
The estimate for compound 4 lay 1.3 percentage points below the measured number; the measured number falls inside the stated range.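

In this assay, methyl in place of hydrogen on the saturated chain gives a number 2.1 percentage points higher from compound 3 to compound 4 (within the scatter), and this change does not carry over in size from the core of compound 1 to the core of compound 3: the same change on two cores in this assay, a number 64.3 percentage points higher (beyond the scatter) from compound 1 to compound 2 and a number 2.1 percentage points higher (within the scatter) from compound 3 to compound 4, 62.2 percentage points apart, beyond the scatter of two such steps.
The pentyl change gives a number 4.4 percentage points higher from compound 2 to compound 4 (within the scatter) and likewise differs from its earlier counterpart on the core of compound 1: the same change on two cores in this assay, a number 66.6 percentage points higher (beyond the scatter) from compound 1 to compound 3 and a number 4.4 percentage points higher (within the scatter) from compound 2 to compound 4, 62.2 percentage points apart, beyond the scatter of two such steps.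
The hexyl change gives a number 68.7 percentage points higher from compound 1 to compound 4 (beyond the scatter), so every large step in the series starts from compound 1, while compound 2, compound 3 and compound 4 stay within the scatter of one another; this shows that the size of a chain extension depends on the core it starts from, but not what sets compound 1 apart.

Chains shorter than that of compound 1 and a longer chain than that of compound 4 remain open. So do an amine or a carboxylic acid at the chain end, and whether the same pattern holds at other concentrations.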